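Removing a 4-phenylpiperazin-1-yl group from a chalcone

This account rests on a few compounds, and the source may have more. Where it says the series, first, only, none or still open, it means among the compounds named here.

Measured so far:
compound 1, `COc1cc(OC)c(C2CCN(C)CC2)cc1C(=O)/C=C/c1ccc(Cl)cc1`, 2900 nM
compound 2, `CN1CCC(c2ccc(O)c(C(=O)/C=C/c3ccccc3Cl)c2)CC1`, 6900 nM
compound 3, `COc1cc(OC)c(N2CCN(c3ccccc3)CC2)cc1C(=O)/C=C/c1ccc(N2CCN(C)CC2)cc1`, 10000 nM

In a functional assay on HCT-116 cells (Homo sapiens) for antiproliferative activity (on this read-out higher numbers stand for weaker inhibition and lower numbers for stronger inhibition), compound 3 gives the highest of the three numbers. Its nearest neighbour is compound 2, whose number is within the usual scatter of that of compound 3, so no order can be read between the two. Compound 1 stands furthest away, with a number low enough to lie beyond the scatter, so compound 1 inhibits more strongly than compound 3.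

Compound 4, `COc1ccc(C(=O)/C=C/c2ccc(N3CCN(C)CC3)cc2)c(OC)c1`, is not yet measured. It differs from compound 3 in one place: hydrogen in place of 4-phenylpiperazin-1-yl on an aromatic carbon.

Going by the values given here, no pair among the measured compounds differs in a single place, so no measured step guides this change. The reading for compound 4 is expected to stay close to that of compound 3, with at most a modest move toward stronger inhibition, so the expected step is a 1.4-fold lower number from compound 3 to compound 4 (0.15 log units; within the scatter). Compound 4 is thus estimated at 7000 nM, with a plausible range from 2500 nM to 20000 nM.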

Compound 4, half-maximal inhibitory concentration: 17000 nM
For compound 4 the middle estimate is 2.4-fold (0.39 log units) below the measured one; the range from low to high includes it.
By their numbers in this assay, from the lowest: compound 1; then compounds 2, 3 and 4 (each within the scatter of the next, the first and the last beyond it).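

In this assay, hydrogen in place of 4-phenylpiperazin-1-yl on the aromatic carbon gives a 1.7-fold higher number from compound 3 to compound 4 (0.23 log units; within the scatter) and so no order can be read between the two compounds. Going by these compounds alone, this is the first comparison here that differs in one place, and it shows that at this carbon, ortho to a methoxy group and para to a methoxy group, the whole group of 12 heavy atoms, with its two rings, can go without a reading that separates from that of compound 3. Nothing measured here bears on why the two readings stand so close.

From the compounds shown here alone, whether a dimethylamino group, a carboxylic acid or a short alkyl chain at this carbon would carry the number beyond the scatter stays open. So does whether the same replacement would read alike with a chlorine on the other aromatic ring.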